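Cytotoxicity of compound 4 in the sulfone series

A few compounds are considered here, and "the series" means these few. Any claim that something is new, unique, unknown or untested is made for them only; others in the source may bear on it.

Among the compounds with values here, in an ADME assay on cells (Homo sapiens) for cytotoxicity, read by resazurin assay, with a stated time of 5 days (a lower number here means that less compound is tolerated, a higher number that more compound is tolerated), compound 2 `COc1ccc(Nc2nc(CS(=O)(=O)c3cccc(Cl)c3)nc3ccsc23)cc1` gives 60000 nM, the only actual number in this small set. Compound 1 `COc1ccc(-c2nc(C3(S(=O)(=O)c4cccc(Cl)c4)CC3)nc3ccsc23)cn1` reads > 50000 nM, which is a limit of the assay. Compound 3 `COc1ccc(-c2nc(CSc3cccc(Cl)c3Cl)nc3ccsc23)cn1` reads > 50000 nM, again a limit. Compound 4 `COc1ccc(-c2nc(CS(=O)(=O)c3cccc(Cl)c3)nc3ccsc23)cc1` carries 4-methoxyphenyl in place of the (4-methoxyphenyl)amino of compound 2 on an aromatic carbon, next to the ring nitrogen (4-methoxyphenyl in place of (4-methoxyphenyl)amino on an aromatic carbon). Within the data shown here, no step between measured compounds is available to size this change. The expected 1.1-fold lower number from compound 2 to compound 4 (0.04 log units; within the scatter) lies within the usual scatter, in no set direction, because of the limit of > 50000 nM in this assay, at which 2 of the 3 values shown sit. For compound 4 the estimated value is 55000 nM, with an expected range of 25000 nM to 100000 nM.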

Compound 4, half-maximal cytotoxic concentration: 69000 nM
Compound 4: middle estimate off by 1.3-fold (0.10 log units), on the low side; the measured number falls inside the stated range.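

In this assay, within the data shown here, 4-methoxyphenyl in place of (4-methoxyphenyl)amino on an aromatic carbon gives a 1.2-fold higher number from compound 2 to compound 4 (0.06 log units; within the scatter), the only step here that joins two actual numbers. On this carbon, next to the ring nitrogen, the hydrogen-bond donor of the (4-methoxyphenyl)amino can go without the reading leaving the scatter. The step gives only a narrow view of this position because so many readings in the set are not actual numbers: the limit of > 50000 nM in this assay, at which 2 of the 4 values shown sit.

As far as these compounds go, whether an aliphatic amine or a carboxylic acid on this aromatic carbon would give a number beyond the scatter stays open.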